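Naphthyl replacement for the formylphenyl group in compound 3

This account rests on a few compounds, and the source may have more. Where it says the series, first, only, none or still open, it means among the compounds named here.

Among the measured compounds shown here, compound 3 `O=Cc1ccc(-c2cn3ccnc3c(-c3ccc4ncn(Cc5ccccc5)c4c3)n2)cc1` stands highest of the three numbers measured so far: in a functional assay on UO-31 cells (Homo sapiens) for inhibition, read by sulforhodamine B assay, with a stated time of 48 h, tested at 10 uM (on this read-out lower numbers stand for less inhibition and higher numbers for more inhibition at the one concentration tested (going by the name of the read-out)), compound 3 gives 82.2%. Compound 1 `CCc1ccc(-c2cn3ccnc3c(-c3ccc4ncn(Cc5ccccc5)c4c3)n2)cc1` gives 57.9% in this assay, and compound 2 `Cc1cccc(-c2cn3ccnc3c(-c3ccc4ncn(Cc5ccccc5)c4c3)n2)c1` gives 41.7%. Both steps that reach compound 3 lie beyond the scatter, a number 24.3 percentage points higher from compound 1 to compound 3 (beyond the scatter) and a number 40.5 percentage points higher from compound 2 to compound 3 (beyond the scatter), while the step of a number 16.2 percentage points lower from compound 1 to compound 2 (beyond the scatter) runs the other way.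

Compound 4 `c1ccc(Cn2cnc3ccc(-c4nc(-c5cccc6ccccc56)cn5ccnc45)cc32)cc1` differs from compound 3 in one place: naphthalen-1-yl in place of 4-formylphenyl on an aromatic carbon. The two steps into compound 3 are the ones that bear here, since both brought in the formyl group; compound 4 gives that group up, and the entering group carries no hydrogen-bond acceptor, as in compound 1 and compound 2. A downward step in this assay is therefore expected, of a size comparable to those two steps reversed. Compound 4 is thus expected to fall back toward the numbers of compound 1 and compound 2. The step this expectation means is a number 32.2 percentage points lower from compound 3 to compound 4 (beyond the scatter). For compound 4 the estimate in this assay is 50%, with a range from 30% to 70%.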

Compound 4, a percentage reported as inhibition, at one concentration (the size of the read-out at that concentration, not a potency): 31.3%
The estimate for compound 4 lay 18.7 percentage points above the measured number, within the range that was stated.
By their numbers in this assay, from the lowest: compound 4; then compound 2; then compound 1; then compound 3.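

In this assay, naphthalen-1-yl in place of 4-formylphenyl brings a large loss, a number 50.9 percentage points lower from compound 3 to compound 4 (beyond the scatter), and the number does not stop level with the two other compounds that lack the formyl group. It lies under both, with a number 10.4 percentage points lower from compound 2 to compound 4 (beyond the scatter) and a number 26.6 percentage points lower from compound 1 to compound 4 (beyond the scatter), which makes compound 4 the lowest of the four. Enlarging the aryl group to two aromatic rings therefore does not make up for the loss of 4-formylphenyl, and among these four compounds the one with a hydrogen-bond acceptor on this aryl group stands highest, with none going against this, though it rests on compound 3 alone.

No evidence at hand bears on the cause of these steps. Going by these compounds, whether a carboxylic acid or a hydroxymethyl group in place of the formyl group would hold the number of compound 3 remains open.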